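Ethyl for methoxy on the aryl urea of compound 1

The source may report more compounds than this note shows. Statements on the series, on what has been measured and on what is new or still open speak of the compounds shown alone.

Compound 1 `COc1ccc(NC(=O)Nc2cc(C)nc3ccccc23)cc1` stands only at a limit in an ADME assay on HEK293 cells (Homo sapiens) for cytotoxicity, with a stated time of 72 h; a higher number here means that more compound is needed for the effect, a lower number that less compound is needed. In this assay compound 1 gives > 25000 nM, which is a limit of the assay and not a number. Compound 2 `COc1ccc(NC(=O)Nc2cc(C)nc3ccccc23)cc1F` gives > 25000 nM in this assay, again a limit. Compound 3 `Cc1cc(NC(=O)Nc2cc(F)cc(F)c2)c2ccccc2n1` gives > 25000 nM in this assay, also a limit. Among the compounds with values here, the only measured step in one place, fluoro in place of hydrogen on an aromatic carbon, is a step that the two limits leave unreadable from compound 1 to compound 2. Within the data shown here, all three values sit at the limit of > 25000 nM in this assay, at which 3 of the 3 values shown sit, so no step can be read in size.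

Compound 4 `CCc1ccc(NC(=O)Nc2cc(C)nc3ccccc23)cc1` differs from compound 1 by ethyl in place of methoxy on an aromatic carbon. Among the measured compounds shown here, no measured step bears on an exchange of this kind, and every value so far is a limit, so the expectation for compound 4 in this assay rests on the series staying at the limit rather than on any readable step. Compound 4 is therefore expected to give 40000 nM in this assay, in the range 20000 nM to 100000 nM. The estimated step is a step that the limit leaves unreadable from compound 1 to compound 4, most likely again a limit.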

Compound 4, half-maximal effective concentration: 16000 nM
Compound 4: middle estimate off by 2.5-fold (0.40 log units), on the high side, outside the stated range (below it).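

In this assay, compound 4 is the first compound shown that gives a number and not a limit, so this position, para to a large group, is one where a single exchange can bring the value into the readable range, while the others stay at the limit: the limit of > 25000 nM in this assay, at which 3 of the 4 values shown sit.

The exchange of ethyl for methoxy gives an at least 1.5-fold lower number from compound 1 to compound 4 (0.19 log units; that floor lies within the scatter). One end of that step is a limit of the assay, so the direction is shown but the true size is not fixed.

From the compounds shown here alone, whether the number follows the loss of the methoxy oxygen or the presence of the ethyl chain stays open, and a longer chain such as propyl or an amine at this position would bear on that. Going by these compounds, it also stays open whether the fluoro or difluoro patterns of compound 2 and compound 3 would read differently on an ethyl-bearing ring.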